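This account rests on a few compounds, and the source may have more. Where it says the series, first, only, none or still open, it means among the compounds named here.

Of the compounds shown here, three with a shared core have been tested in an assay for inhibition of prostacyclin synthase (Homo sapiens), using microsomes; a lower number here means a stronger inhibitor, a higher number a weaker inhibitor. Compound 1 `COc1ccc(OC(C)(C)C2OCC(C/C=C\CCC(=O)O)C(c3cccnc3)O2)cc1` reaches only the upper limit of the method, > 100000 nM, so for it no number is known, as noted in the limit of > 100000 nM in this assay, at which 1 of the 3 values shown sits. Compound 2 `Cc1ccc(OC(C)(C)C2OCC(C/C=C\CCC(=O)O)C(c3cccnc3)O2)cc1` gives 25000 nM. Compound 3 `COc1ccccc1OC(C)(C)C1OCC(C/C=C\CCC(=O)O)C(c2cccnc2)O1` gives 51000 nM, the higher of the two real numbers, and the step of a 2.0-fold higher number from compound 2 to compound 3 (0.31 log units; beyond the scatter) places it as the weaker of the pair. The steps of an at least 4.0-fold lower number from compound 1 to compound 2 (0.60 log units; beyond the scatter) and an at least 1.9-fold lower number from compound 1 to compound 3 (0.29 log units; that floor lies within the scatter) start from a limit, so only their floors are known.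

Compound 4 `CC(C)(Oc1ccccc1O)C1OCC(C/C=C\CCC(=O)O)C(c2cccnc2)O1` differs from compound 3 by one change: hydrogen in place of methyl on an oxygen on an aromatic ring. Among the measured compounds shown here, none of the measured steps removes a methyl from an oxygen; the closest, the step from compound 1 to compound 2, exchanged a methoxy for a methyl and was of modest size. For the measured compounds named here, with no direct precedent, a step of about a 1.0-fold lower number from compound 3 to compound 4 (0.01 log units; within the scatter) is expected, which is essentially no change beyond the scatter. Compound 4 is therefore estimated at 50000 nM, with a likely range from 15000 nM to 150000 nM.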

Compound 4, half-maximal inhibitory concentration: > 100000 nM
Compound 4 ended at the assay's limit; the forecaster's own chance of this, stated with the estimate: 25%; middle value at least 2.0-fold (0.30 log units) away from the limit.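

Hydroxy in place of methoxy on the 2-substituted phenyl brings no gain here: in this assay compound 4 gives > 100000 nM, which is a limit of the assay and not a number. The change gives an at least 1.9-fold higher number from compound 3 to compound 4 (0.29 log units; that floor lies within the scatter), so a real weakening by this change alone is not proven, while the comparison with the methyl-bearing compound, an at least 4.0-fold higher number from compound 2 to compound 4 (0.60 log units; beyond the scatter), does clear the scatter. The step between compound 1 and compound 4 cannot be read, because both compounds sit at the same limit: the limit of > 100000 nM in this assay, at which 2 of the 4 values shown sit.

On these data alone, how far beyond its limit compound 4 truly lies stays open, so the full size of the step is unknown. Also open, as far as these compounds go, is whether an amine in place of this hydroxy, or an ethyl on this oxygen, would bring the number closer to that of compound 2.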